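Cinnamate esters of a trimethoxyphenyl propenol: aryl variation

The source may hold more compounds than are shown below. What is called first, only, known or untested is meant among the compounds shown, and "the series" means these compounds.

Measured so far:
compound 1, `COc1cc(OC)c(OC)cc1/C=C/COC(=O)/C=C/c1ccc(Br)cc1`: 25%
compound 2, `COc1cc(OC)c(OC)cc1/C=C/COC(=O)/C=C/c1ccccc1C(F)(F)F`: 50%

In a functional assay on the whole organism (strain Kunming) with Mus musculus as the target, with a stated time of 0.5 h, at a dose of 300 mg/kg by the intraperitoneal route (a higher number here means a weaker effect of the compound at the dose given, a lower number a stronger effect), compound 1 gives 25% and compound 2 gives 50%. For the measured compounds named here, the one measured step, a number 25 percentage points higher from compound 1 to compound 2 (beyond the scatter), is the only comparison available. Compound 2 therefore stands highest of the two numbers, with compound 1 the nearest and beyond the scatter below it.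

Compound 3, `COc1cc(OC)c(OC)cc1/C=C/COC(=O)/C=C/c1cccc(Br)c1`, is not yet measured. It differs from compound 2 as follows: 3-bromophenyl in place of 2-(trifluoromethyl)phenyl on a double-bonded chain carbon bound to a double-bonded chain carbon. The step from compound 1 to compound 2 bears on this change, since it exchanged a bromophenyl for the 2-(trifluoromethyl)phenyl; reversing that exchange, now toward a 3-bromophenyl, is expected to move the number back down in this assay. Going by the values given here, no measured pair tells how a 3-bromophenyl compares with a 4-bromophenyl, so the expected step is hedged. Compound 3 is expected to show a number 18 percentage points lower from compound 2 to compound 3 (beyond the scatter), landing at 32%, within 15% to 50%.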

Compound 3, a percentage reported as activity, at one dose (the size of the read-out at that dose, not a potency): 25%
For compound 3 the middle estimate is 7 percentage points above the measured one; the range from low to high includes it.
By their numbers in this assay, from the lowest: compounds 1 and 3 (each within the scatter of the next); then compound 2.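

In this assay, 3-bromophenyl in place of 2-(trifluoromethyl)phenyl gives a number 25 percentage points lower from compound 2 to compound 3 (beyond the scatter) and thus shows that a second aryl group at this place on the chain differs from the 2-(trifluoromethyl)phenyl group, not only the 4-bromophenyl group of the first step. 3-bromophenyl in place of 4-bromophenyl gives no change at the digits printed from compound 1 to compound 3 (within the scatter) and so the two bromophenyl compounds cannot be told apart in this read-out. Nothing available on these compounds accounts for the gap between the bromophenyl groups and the 2-(trifluoromethyl)phenyl group.

Open, as far as these compounds go, is whether the higher number of compound 2 follows the trifluoromethyl group itself or its place on the ring. Also open, from the compounds shown here alone, is how an aryl group carrying an amine or a carboxylic acid would read at this place on the chain.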